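Swapping the Aryl Group on the Sulfonyl and Expected Clearance

The source may report more compounds than this note shows. Statements on the series, on what has been measured and on what is new or still open speak of the compounds shown alone.

Three close analogues sharing one core have been examined in an ADME assay on microsomes from liver (Homo sapiens) for metabolic stability, tested at 2.5 uM; on this read-out lower numbers stand for slow clearance and higher numbers for fast clearance. Compound 1, `O=S(=O)(c1ccc(F)c(Cl)c1)c1cnc2cc(F)ccc2c1-c1ccc(Cl)cc1`, gives 0.39 mL/min in this assay. Compound 2, `O=S(=O)(c1ccc(F)cc1)c1cnc2cc(F)ccc2c1-c1cccc(F)c1`, gives 0.95 mL/min, and compound 3, `COc1ccc(S(=O)(=O)c2cnc3cc(F)ccc3c2-c2ccc(F)cc2)cc1Cl`, gives 1.29 mL/min. Compound 1 therefore stands lowest of the three, with compound 2 a step above it that lies beyond the scatter and compound 3 further above it, also beyond the scatter.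

The next compound, compound 4, `COc1ccc(S(=O)(=O)c2cnc3cc(F)ccc3c2-c2ccc(Cl)cc2)cc1`, has not yet been measured in this assay. Its structure differs from compound 1 in a single place: 4-methoxyphenyl in place of 3-chloro-4-fluorophenyl on a sulfonyl sulfur. The 4-chlorophenyl group on the core is kept unchanged.

Among the measured compounds, compound 3 is the one whose sulfonyl carries a methoxy-bearing aryl group, and in this assay compound 3 gives 1.29 mL/min, the highest of the three numbers. On that basis the step of a 2.6-fold higher number from compound 1 to compound 4 (0.41 log units; beyond the scatter) is expected to be upward and beyond the scatter. Compound 4 is estimated to give 1 mL/min in this assay, within a range from 0.5 mL/min to 2 mL/min.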

Compound 4, intrinsic clearance in a liver preparation (reported as CLH), per the amount of preparation that the assay uses: 1.28 mL/min
Compound 4: the middle estimate sits 1.3-fold (0.11 log units) below what was measured, and the stated range covers the measured number.
By their numbers in this assay, from the lowest: compound 1; then compounds 2, 4 and 3 (each within the scatter of the next).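

Going by these compounds alone, with the 4-chlorophenyl group on the core held constant, compound 1 and compound 4 form the first pair here that differs in one place only, so the group on the sulfonyl sulfur can now be read on its own in this assay. Placing 4-methoxyphenyl where 3-chloro-4-fluorophenyl stood gives a 3.3-fold higher number from compound 1 to compound 4 (0.52 log units; beyond the scatter), a modest step but one beyond the scatter, showing that this position alone can move the read-out even though both groups are six-membered aromatic rings of carbon only and carry no net charge. Nothing available accounts for this step.

Within the data shown here, the single pair leaves open which part of the exchange carries the step, since the chlorine and fluorine leave and the methoxy group enters together, and their separate contributions cannot be told apart. Going by these compounds, how an amine, a carboxylic acid or a longer chain such as ethoxy on this aryl group would behave in this assay also remains open.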